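The source may report more compounds than this note shows. Statements on the series, on what has been measured and on what is new or still open speak of the compounds shown alone.

Compound 1, `COc1cc([C@](O)(CCN(C)C)[C@@H](c2cc3cc(C#N)ccc3nc2OC)c2cccc(OC)c2F)cc(SC)n1`: 36 uL/min
Compound 2, `COc1cccc([C@H](c2cc3cc(C#N)ccc3nc2OC)[C@@](O)(CCN(C)C)c2cc(SC)nc(SC)c2)c1F`: 20 uL/min
Compound 3, `CCSc1cc([C@](O)(CCN(C)C)[C@@H](c2cc3cc(Br)ccc3nc2OC)c2cccc(OC)c2F)cc(SCC)n1`: 12 uL/min

All three compounds were run in an ADME assay on microsomes from liver (Mus musculus) for metabolic stability; a higher number here means faster removal of the compound, a lower number slower removal. The number for compound 3 sits below that of compound 1 by more than the usual scatter, while the number for compound 2 lies within the scatter of compound 3, so the two cannot be separated. For the measured compounds named here, the only change isolated between two measured compounds is the one in a 1.8-fold lower number from compound 1 to compound 2 (0.26 log units; within the scatter), which concerns the substituents on the core and not the fused ring system.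

Compound 4, `CCSc1cc([C@](O)(CCN(C)C)[C@@H](c2cc3cc(C#N)ccc3nc2OC)c2cccc(OC)c2F)cc(SCC)n1`, differs from compound 3 in one place: cyano in place of bromo on an aromatic carbon. Going by the values given here, no measured pair isolates this exchange of bromo for cyano, and the methylsulfanyl-for-methoxy step between compound 1 and compound 2 does not bear on it. Compound 1 does carry the cyano group, but it also differs from compound 3 in the sulfanyl chains, so its number offers no clean guide.

Among the compounds with values here, with no measured step on this change, compound 4 is expected to give a number in this assay within the scatter of compound 3, a step of no change at the digits printed from compound 3 to compound 4 (within the scatter). Compound 4 is therefore estimated at 12 uL/min, with a range from 6 uL/min to 26 uL/min.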

Compound 4, intrinsic clearance in a liver preparation (reported as CLH), per the amount of preparation that the assay uses: 27 uL/min
Compound 4: the middle estimate sits 2.3-fold (0.35 log units) below what was measured; measured number above the stated range.
By their numbers in this assay, from the lowest: compounds 3, 2, 4 and 1 (each within the scatter of the next, the first and the last beyond it).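

this assay now gives a measured step for the exchange of bromo for cyano on this aromatic carbon, a change that no earlier pair isolated: a 2.3-fold higher number from compound 3 to compound 4 (0.35 log units; beyond the scatter), a modest step that lies beyond the scatter. With cyano held in place, exchanging the substituted six-membered aromatic ring gives a 1.4-fold higher number from compound 2 to compound 4 (0.13 log units; within the scatter) and a 1.3-fold lower number from compound 1 to compound 4 (0.12 log units; within the scatter), both within the scatter, so among compounds 1, 2 and 4 these ring changes do not separate the numbers, whereas the bromo-to-cyano exchange does separate compound 3 from compound 4. Nothing in the information available accounts for the size or direction of this step.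

Bromo occurs only in compound 3, so the compounds shown cannot tell whether the same exchange gives a similar step when methylsulfanyl or methoxy groups stand on the other ring. On these data alone, it also remains open where a chloro group, a methyl group or a primary amide on the same aromatic carbon would fall relative to bromo and cyano.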